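Swapping 3-methoxyphenyl for 4-bromophenyl

A few compounds are considered here, and "the series" means these few. Any claim that something is new, unique, unknown or untested is made for them only; others in the source may bear on it.

In a functional assay on PC-3 cells (Homo sapiens) for inhibition, read by MTT assay, with a stated time of 48 h (a lower number here means a stronger inhibitor, a higher number a weaker inhibitor), compound 1 `COc1ccc(Nc2nnc(Cl)c(Nc3cc(OC)c(OC)c(OC)c3)n2)cc1` gives 13500 nM and compound 2 `COc1cccc(Nc2nnc(Cl)c(Nc3cc(OC)c(OC)c(OC)c3)n2)c1` gives 11300 nM so the two stand within the scatter of each other. Compound 3 `COc1cc(Nc2nc(Nc3ccc(Br)cc3)nnc2Cl)cc(OC)c1OC` differs from compound 2 by 4-bromophenyl in place of 3-methoxyphenyl on a nitrogen on an aromatic ring with 4-bromophenyl in place of 3-methoxyphenyl on a nitrogen on an aromatic ring. Within the data shown here, the only measured step bearing on this is a 1.2-fold lower number from compound 1 to compound 2 (0.08 log units; within the scatter) and it merely exchanges one methoxyphenyl for another, so no bromine-bearing compound has yet been measured. No change beyond the scatter is therefore expected in this assay and the expected step is a 1.1-fold lower number from compound 2 to compound 3 (0.05 log units; within the scatter) with wide uncertainty. Compound 3 is estimated at 10000 nM within an expected range from 4000 nM to 25000 nM in this assay.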

Compound 3, half-maximal inhibitory concentration: 8990 nM
Beside the measured number, compound 3's estimate is 1.1-fold (0.05 log units) above it; the range from low to high includes it.
By their numbers in this assay, from the lowest: compounds 3, 2 and 1 (each within the scatter of the next).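

With 4-bromophenyl in place of 3-methoxyphenyl on a nitrogen on an aromatic ring (a 1.3-fold lower number from compound 2 to compound 3 (0.10 log units; within the scatter)), a ring carrying bromine rather than a methoxy group stays within the scatter in this assay. Bromo in place of methoxy on an aromatic carbon (a 1.5-fold lower number from compound 1 to compound 3 (0.18 log units; within the scatter)) adds a direct exchange of the two groups, also within the scatter. No supporting evidence bears on this result. As far as these compounds go, whether an amine, a carboxylic acid or a longer chain on this phenyl ring would give a step beyond the scatter stays open.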